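A few compounds are considered here, and "the series" means these few. Any claim that something is new, unique, unknown or untested is made for them only; others in the source may bear on it.

Measured in a functional assay on C8166 cells (Homo sapiens) for cytotoxicity, read by MTT assay; on this read-out lower numbers stand for higher toxicity in this test and higher numbers for lower toxicity in this test:

- Compound 1 `Cc1cc(S(N)(=O)=O)ccc1NC(=O)COc1ccc(Cl)cc1NC(=O)c1cccc(C(F)(F)F)c1` gives 124000 nM
- Compound 2 `Cc1ccc(C)c(C(=O)Nc2cc(Cl)ccc2OCC(=O)Nc2ccc(S(N)(=O)=O)cc2C)c1` gives 79700 nM
- Compound 3 `Cc1cc(S(N)(=O)=O)ccc1NC(=O)COc1ccc(Cl)cc1NC(=O)c1cc(Cl)cc(Br)c1` gives 114000 nM

Compound 3 sits level with the other two within the scatter, as shown by a 1.1-fold lower number from compound 1 to compound 3 (0.04 log units; within the scatter) and by a 1.4-fold higher number from compound 2 to compound 3 (0.16 log units; within the scatter). The next compound, compound 4 `Cc1cc(S(N)(=O)=O)ccc1NC(=O)COc1ccc(Cl)cc1NC(=O)c1ccc2ccccc2c1`, keeps the shared core and has naphthalen-2-yl in place of 3-bromo-5-chlorophenyl on a carbonyl carbon.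

The measured steps that bear on this change are exchanges at that same carbonyl carbon. Besides the two above, there is a 1.6-fold lower number from compound 1 to compound 2 (0.19 log units; within the scatter). All three stay within the scatter, so the aryl groups tried here have not moved the number in this assay. Among the compounds with values here, none of the measured compounds carries naphthalen-2-yl, so this expectation is an extrapolation.

No step beyond the scatter is expected, and the estimated step is a 1.1-fold lower number from compound 3 to compound 4 (0.06 log units; within the scatter). The expected value for compound 4 is 100000 nM, with an estimated range from 58000 nM to 170000 nM.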

Compound 4, half-maximal cytotoxic concentration: 37600 nM
Compound 4: the middle estimate sits 2.7-fold (0.42 log units) above what was measured; the measured number lies below the stated range.
By their numbers in this assay, from the lowest: compound 4; then compounds 2, 3 and 1 (each within the scatter of the next).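

In this assay, the group on this carbonyl carbon turns out to matter: naphthalen-2-yl gives a 3.0-fold lower number from compound 3 to compound 4 (0.48 log units; beyond the scatter), a 2.1-fold lower number from compound 2 to compound 4 (0.33 log units; beyond the scatter) and a 3.3-fold lower number from compound 1 to compound 4 (0.52 log units; beyond the scatter), whereas the three single-ring groups stayed level within the scatter. Within the data shown here, all three steps are modest, but they make compound 4, the only compound here with 2 six-membered aromatic rings, the most toxic of the four in this test. Nothing measured here explains why the number falls with this change.

The compounds shown leave open whether the second ring itself drives the drop or whether its particular placement matters, a question that a naphthalen-1-yl or a biphenyl group could address. They also leave open how a ring carrying nitrogen, such as a quinoline, or an added amine or carboxylic acid would behave at this carbonyl carbon.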